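Methyl on the sulfonyl phenyl: two placements compared

The compounds below may be only part of what the source reports. "The series", "measured", "known", "first", "only" and "open" are said of these compounds alone.

Measured so far in a functional assay (trachea) for antagonist activity, with Cavia porcellus as the target; on this read-out lower numbers stand for lower potency and higher numbers for higher potency (the scale is a negative logarithm):
- compound 1 `COc1cc(C(=O)NS(=O)(=O)c2ccccc2)ccc1Cn1ncc2ccc(NC(=O)CC3CCCC3)cc21`: 10.5
- compound 2 `CCCCC(CC)C(=O)Nc1ccc2ccn(Cc3ccc(C(=O)NS(=O)(=O)c4ccccc4)cc3OC)c2c1`: 8.6
- compound 3 `CCCCC(CC)C(=O)Nc1ccc2ccn(Cc3ccc(C(=O)NS(=O)(=O)c4ccc(C)cc4)cc3OC)c2c1`: 8.4

Compound 1 stands highest of the three in this assay; compound 2 and compound 3 both lie well below it, and those gaps are beyond the scatter. How the core of compound 1 differs from that of compound 2 is not broken down here.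

Within the pair that shares a core, one change is counted: methyl in place of hydrogen on an aromatic carbon. It made a number 0.20 log units lower from compound 2 to compound 3 (within the scatter), a step within the scatter, so no order between compound 2 and compound 3 can be read from it.

Compound 4 `COc1cc(C(=O)NS(=O)(=O)c2ccccc2C)ccc1Cn1ncc2ccc(NC(=O)CC3CCCC3)cc21` is compound 1 with the same kind of change, not the same one: methyl in place of hydrogen on an aromatic carbon. The place lines differ in one point, the methyl of compound 4 sitting ortho to a large group where that of compound 3 sits para to a large group. Among the measured compounds shown here, no measured pair shows a methyl at this place, so the only footing is the para case.

Resting on compound 1 at 10.5 and on the small step seen from compound 2 to compound 3, the step from compound 1 to compound 4 is expected to be a number 0.30 log units lower from compound 1 to compound 4 (within the scatter), with the range widened because the placement is untested. Compound 4 is thus estimated at 10.2 in this assay, between 9.4 and 10.8.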

Compound 4, negative logarithm of the antagonist equilibrium constant: 10.9
Compound 4: the middle estimate sits 0.70 log units below what was measured; measured number above the stated range.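

In this assay, methyl in place of hydrogen on an aromatic carbon gives a number 0.40 log units higher from compound 1 to compound 4 (beyond the scatter), and this step does not match the one seen on the other core: the same change on two cores in this assay, a number 0.20 log units lower (within the scatter) from compound 2 to compound 3 and a number 0.40 log units higher (beyond the scatter) from compound 1 to compound 4, 0.60 log units apart, beyond the scatter of two such steps

So within this series, the step measured on one core cannot be carried to the other as a fixed increment, in size or in direction. Among the compounds shown here, this does not show that the core is what sets the step: the methyl of compound 4 sits ortho to a large group, that of compound 3 sits elsewhere on the phenyl, and the two pairs therefore differ in both core and placement, with only one pair on each core.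

Still open, as far as these compounds go, is how a methyl at the place it holds in compound 3 would read on the core of compound 1, and how a 2-methylphenyl would read on the core of compound 2; these two pairs would separate the core from the placement. Also open, from the compounds shown here alone, is whether a chlorine or an ethyl in the place of the methyl of compound 4 would give a step like a number 0.40 log units higher from compound 1 to compound 4 (beyond the scatter).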